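The compounds below may be only part of what the source reports. "The series", "measured", "known", "first", "only" and "open" are said of these compounds alone.

Measured so far:
compound 1, `Cn1nc2c(=O)n(CC3(O)CCN(Cc4ccc(-c5ccco5)cc4Cl)CC3)cnc2c1-c1ccc(C2(N)CC2)cc1`, 66.1 nM
compound 2, `Cn1nc2c(=O)n(CC3(O)CCN(Cc4ccc(-c5ncco5)cc4Cl)CC3)cnc2c1-c1ccc(CN)cc1`, 1120 nM

In an assay on isolated protein for inhibition of ubiquitin carboxyl-terminal hydrolase 7 (Homo sapiens), with stated times of 30 min and 2 h (a higher number here means a weaker inhibitor, a lower number a stronger inhibitor), compound 2 has the higher of the two numbers, and compound 1 gives a lower value, a gap beyond the usual scatter. Within the data shown here, the two compounds differ in more than one place, so no single step between them can be read off.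

Compound 3, `Cc1ccc(-c2ccc(CN3CCC(O)(Cn4cnc5c(-c6ccc(CN)cc6)n(C)nc5c4=O)CC3)c(Cl)c2)s1`, has not yet been measured. It differs from compound 2 by 5-methylthiophen-2-yl in place of 1,3-oxazol-2-yl on an aromatic carbon.

Among the measured compounds shown here, with no directly comparable step available, only a modest change is expected from compound 2 to compound 3 in this assay, a step of a 2.5-fold lower number from compound 2 to compound 3 (0.40 log units; beyond the scatter) toward a lower number. For compound 3 the estimate is 450 nM, in the range 130 nM to 1600 nM.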

Compound 3, half-maximal inhibitory concentration: 101 nM
Compound 3: the middle estimate sits 4.5-fold (0.65 log units) above what was measured, outside the stated range (below it).
By their numbers in this assay, from the lowest: compounds 1 and 3 (each within the scatter of the next); then compound 2.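

In this assay, among these compounds, this is the first comparison in which only one place changes: 5-methylthiophen-2-yl in place of 1,3-oxazol-2-yl, para to a large group and meta to a chloro group, gives an 11-fold lower number from compound 2 to compound 3 (1.04 log units; beyond the scatter) as a large step. The group at this position therefore has a strong bearing on the inhibition read-out when the rest of compound 2 is held constant. No available evidence accounts for this step. Going by these compounds, whether a thiophene without the methyl group, or a phenyl ring, would give a similar value remains open.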